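The source may hold more compounds than are shown below. What is called first, only, known or untested is meant among the compounds shown, and "the series" means these compounds.

Of the compounds shown here, three sharing one core have been tested in a functional assay on HCT-116 cells (Homo sapiens) for antiproliferative activity, read by MTT assay, with a stated time of 48 h; on this read-out higher numbers stand for weaker inhibition and lower numbers for stronger inhibition. Compound 1 `CCCCCC(CCO)n1cnc2c(NC)ncnc21` carries a methylamino group and a hexyl branch on its side chain. In this assay compound 1 gives > 50000 nM, which is a limit of the assay and not a number. Compound 2 `CCCCCC(CCO)n1cnc2c(N)ncnc21` differs from compound 1 by methyl in place of hydrogen on a nitrogen on an aromatic ring. In this assay compound 2 gives > 50000 nM, again a limit rather than a number. With both values sitting at the limit of > 50000 nM in this assay, at which 2 of the 3 values shown sit, the step is a step that the two limits leave unreadable from compound 2 to compound 1. Compound 3 `CCCCCCCCCC(CCO)n1cnc2c(NC)ncnc21` carries a butyl in place of hydrogen on a saturated chain carbon, six bonds along the chain from an aromatic nitrogen, and this gives an at least 9.2-fold lower number from compound 1 to compound 3 (0.96 log units; beyond the scatter). In this assay, for the measured compounds named here, compound 3 gives 5410 nM, the only true number among the three. The difference between the cores of compound 2 and compound 3 is not broken down here. Compound 4 `CCCCCCCCCC(CCO)n1cnc2c(N(C)C)ncnc21` is not yet measured and differs from compound 3 by methyl in place of hydrogen on a nitrogen on an aromatic ring. This is the same kind of change as from compound 2 to compound 1, but here the nitrogen's other neighbours are an aromatic carbon and a saturated chain carbon, not an aromatic carbon alone. The earlier step stays unreadable, so little supports a firm forecast. The expected step is a 2.2-fold higher number from compound 3 to compound 4 (0.35 log units; beyond the scatter), a modest weakening. Compound 4 is estimated at 12000 nM, with a range from 3000 nM to 50000 nM.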

Compound 4, half-maximal inhibitory concentration: 9810 nM
Estimate against measurement, compound 4: 1.2-fold (0.09 log units) above; the range from low to high includes it.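

In this assay the change from methylamino to dimethylamino on the core of compound 3 gives a 1.8-fold higher number from compound 3 to compound 4 (0.26 log units; within the scatter), so compound 3 and compound 4 cannot be told apart on this measurement. For the compounds shown here, the same kind of change on the other core, a methyl in place of hydrogen on a nitrogen on an aromatic ring, cannot be read, because compound 1 and compound 2 both give a limit and not a number: the limit of > 50000 nM in this assay, at which 2 of the 4 values shown sit. The series therefore offers only one readable step for this change, which shows nothing about whether it behaves alike on the two cores.

Open, on these data alone, is what an amino group, with no methyl on the nitrogen, would give on the core of compound 3, since that would complete the set of three on one core and allow a second readable comparison. Also open, as far as these compounds go, is what an ethyl group on that nitrogen, a longer chain, or an amine in place of the hydroxyl would give.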